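The source may report more compounds than this note shows. Statements on the series, on what has been measured and on what is new or still open speak of the compounds shown alone.

Measured so far:
compound 1 `CC(O)(C(=O)Nc1cccc(S(=O)(=O)c2ccccc2)c1)C(F)(F)F` — > 30000 nM
compound 2 `CC(O)(C(=O)Nc1ccc(S(=O)(=O)c2ccccc2F)cc1)C(F)(F)F` — 1300 nM
compound 3 `CC(O)(C(=O)Nc1ccc(S(=O)(=O)c2ccccc2)c(C#N)c1)C(F)(F)F` — 3800 nM

In a functional assay (Cavia porcellus) with sulfonylurea receptors; K-ATP channels (Homo sapiens) as the target (a higher number here means a weaker inhibitor, a lower number a stronger inhibitor), compound 1 returns only a limit, > 30000 nM, and no number. It therefore sits at the weak end of the three values, as a limit rather than a measurement (the limit of > 30000 nM in this assay, at which 1 of the 3 values shown sits). Among the compounds with values here, compound 2 gives 1300 nM in this assay and compound 3 gives 3800 nM; no single-point step links either of them to compound 1, so their values stand on their own.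

Compound 4 `CC(O)(C(=O)Nc1ccc(C#N)c(S(=O)(=O)c2ccccc2)c1)C(F)(F)F` is not yet measured in this assay. It differs from compound 1 by cyano in place of hydrogen on an aromatic carbon. With compound 1 known only as a limit, no direction for the step can be read from the data; the expected step of a number no higher from compound 1 to compound 4 (the limit leaves the size open) is small, within the scatter, and compound 4 is expected to give about 30000 nM, between 8000 nM and 100000 nM, with a fair chance that this assay again reports only a limit.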

Compound 4, half-maximal inhibitory concentration: 2600 nM
Compound 4: middle estimate off by 12-fold (1.06 log units), on the high side, outside the stated range (below it).
By their numbers in this assay, from the lowest: compounds 2, 4 and 3 (each within the scatter of the next, the first and the last beyond it). At a limit, above all of these: compound 1.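

In this assay, within the data shown here, cyano in place of hydrogen on an aromatic carbon, ortho to a phenylsulfonyl group and para to a large group, gives the first single-place step: an at least 11-fold lower number from compound 1 to compound 4 (1.06 log units; beyond the scatter). This position therefore tolerates the added cyano, and the change turns a limit into a measured value. The step gives only a minimum size, because compound 1 stands at a limit: the limit of > 30000 nM in this assay, at which 1 of the 4 values shown sits.

As far as these compounds go, whether an amine or a carboxylic acid on the same carbon would give a similar number stays open. So does the size of this cyano step from a measured starting value.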